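Swapping a methoxy for a trifluoromethyl on a pendant ring

A few compounds are considered here, and "the series" means these few. Any claim that something is new, unique, unknown or untested is made for them only; others in the source may bear on it.

Compound 1 `Cc1cc(-c2ccc(F)cc2)c(/C=C/[C@@H]2C[C@@H](O)CC(=O)O2)c(C(C)C)n1`: 9 nM
Compound 2 `CC(C)c1nc(C2CCCCC2)cc(-c2ccc(F)cc2)c1/C=C/[C@@H]1C[C@@H](O)CC(=O)O1`: 4 nM
Compound 3 `COc1ccc(-c2cc(-c3ccccc3)nc(C(C)C)c2/C=C/[C@@H]2C[C@@H](O)CC(=O)O2)cc1`: 13 nM

Of the compounds shown here, three share a core and have been tested in an assay for inhibition of 3-hydroxy-3-methylglutaryl-coenzyme A reductase (Rattus norvegicus); a lower number here means a stronger inhibitor, a higher number a weaker inhibitor. Compound 3 has the highest number of the three, yet its distance from compound 1 is within the scatter, so the two cannot be ranked; only compound 2 clearly stands apart from it, beyond the scatter.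

Compound 4 `CC(C)c1nc(-c2ccccc2)cc(-c2ccc(C(F)(F)F)cc2)c1/C=C/[C@@H]1C[C@@H](O)CC(=O)O1` is a close relative of compound 3: the change is trifluoromethyl in place of methoxy on an aromatic carbon.

For the measured compounds named here, only one measured step exists, a 2.3-fold lower number from compound 1 to compound 2 (0.35 log units; beyond the scatter), and it concerns a different group at a different place, so it says nothing direct about exchanging a methoxy for a trifluoromethyl. Going by the values given here, with no step of the same kind to lean on, the expectation in this assay is a change no larger than the scatter, in no particular direction. Compound 4 is therefore expected to give 15 nM, within a range from 5 nM to 45 nM. That estimate amounts to an expected step of a 1.2-fold higher number from compound 3 to compound 4 (0.06 log units; within the scatter), which is not beyond the scatter.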

Compound 4, half-maximal inhibitory concentration: 36 nM
Compound 4: middle estimate off by 2.4-fold (0.38 log units), on the low side; low and high end bracket the measured number.
By their numbers in this assay, from the lowest: compound 2; then compounds 1 and 3 (each within the scatter of the next); then compound 4.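

In this assay, for the compounds shown here, replacing 4-methoxyphenyl with 4-(trifluoromethyl)phenyl gives a 2.8-fold higher number from compound 3 to compound 4 (0.44 log units; beyond the scatter), the first measured step at this place, showing that the group on this aromatic carbon can shift the number beyond the scatter, here towards a weaker inhibitor. The exchange changes more than one feature at once: the entering trifluoromethyl has more heavy atoms than the methoxy it replaces, and it has no hydrogen-bond acceptor where the methoxy has one. Nothing available here gives a measured explanation for this shift.

The compounds shown leave open how an amine, a nitrile or a carboxylic acid would fare on this aromatic carbon. On these data alone, it also remains open whether the same exchange would give a similar step with cyclohexyl in place of the unsubstituted phenyl on the shared core.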